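The compounds below may be only part of what the source reports. "The series", "measured", "known", "first", "only" and "open" are said of these compounds alone.

Compound 1, `CCC(NC(=O)C(CC(C)C)NC(=O)OCc1ccccc1)C(=O)C(=O)NCCCCCO`, is the simplest of the three compounds considered here; in an assay on isolated protein (Oryctolagus cuniculus) for inhibition of Calpain-2 catalytic subunit (Homo sapiens) (on this read-out higher numbers stand for weaker inhibition and lower numbers for stronger inhibition), compound 1 gives 51 nM. Compound 2, `CCC(NC(=O)C(CC(C)C)NC(=O)OCc1ccccc1)C(=O)C(=O)NCC1(C)CC(O)CC(C)(C)C1`, carries a larger saturated ring in place of the open chain on the amide nitrogen, and in this assay compound 2 gives 69 nM. For the measured compounds named here, the only step measured so far, a 1.4-fold higher number from compound 1 to compound 2 (0.13 log units; within the scatter), shows that the two numbers lie within the scatter of each other, so compound 2 cannot be set apart from compound 1 on this read-out.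

Compound 3, `CCC(NC(=O)C(CC(C)C)NC(=O)OCc1ccccc1)C(=O)C(=O)NCc1ccccc1`, differs from compound 2 in a group of 6 heavy atoms (6 carbon; one six-membered aromatic ring of carbon only) in place of a group of 10 heavy atoms (9 carbon, 1 oxygen; one six-membered non-aromatic ring of carbon only), on a saturated chain carbon bound to an amide-type nitrogen. Going by the values given here, the one step that bears on this position, from the chain of compound 1 to the ring of compound 2, was a 1.4-fold higher number from compound 1 to compound 2 (0.13 log units; within the scatter) and therefore gave no change beyond the scatter; on that evidence the group on this nitrogen appears to be exchanged without much effect on the number. For compound 3 no step beyond the scatter is therefore expected, with a 1.2-fold lower number from compound 2 to compound 3 (0.06 log units; within the scatter) as the expected change, and its inhibition constant in this assay is estimated at 60 nM, in the range 20 nM to 180 nM.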

Compound 3, inhibition constant: 350 nM
Compound 3: middle estimate off by 5.8-fold (0.77 log units), on the low side; the whole stated range lies below it.
By their numbers in this assay, from the lowest: compounds 1 and 2 (each within the scatter of the next); then compound 3.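

In this assay, the group on this saturated chain carbon bound to an amide-type nitrogen proves not to be freely exchangeable: phenyl gives a 5.1-fold higher number from compound 2 to compound 3 (0.71 log units; beyond the scatter) when it replaces the ring group and a 6.9-fold higher number from compound 1 to compound 3 (0.84 log units; beyond the scatter) when it replaces 4-hydroxybutyl, so the lack of change between the chain and the ring group does not extend to every group at this place. The two groups that stay within the scatter of each other differ greatly in shape, yet each carries one oxygen, whereas phenyl has none and is the only one of the three with an aromatic ring. No measurement shown here explains the higher number for compound 3.

In these three compounds the loss of the oxygen and the arrival of the aromatic ring occur together, so their separate contributions cannot be told apart. A cyclohexyl group or a pentyl chain without the hydroxyl, set against a hydroxyphenyl group at the same place, would separate the two changes and show whether either one alone accounts for the step.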